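Methoxy Added to an Inactive Scaffold: Expected Outcome

The compounds below may be only part of what the source reports. "The series", "measured", "known", "first", "only" and "open" are said of these compounds alone.

Measured compounds:
compound 1, `COc1cc(CC(O)(COCc2ccccc2)COCc2ccccc2)nc(OC)n1`, > 100000 nM
compound 2, `COc1cc(CC(O)COCc2ccccc2)nc(OC)n1`, > 100000 nM

In a functional assay on SW-620 cells (Homo sapiens) for antiproliferative activity, read by MTT assay, with a stated time of 72 h (on this read-out lower numbers stand for stronger inhibition and higher numbers for weaker inhibition), compound 1 gives > 100000 nM, which is a limit of the assay and not a number. In this assay compound 2 likewise gives > 100000 nM, again only a limit. The step that the two limits leave unreadable from compound 1 to compound 2 therefore cannot be read in size; what is known is the limit of > 100000 nM in this assay, at which 2 of the 2 values shown sit, so compound 2 stands at that limit with no finer position. Compound 3, `COc1nc(CC(O)COCc2ccccc2)c(OC)c(OC)n1`, differs from compound 2 by methoxy in place of hydrogen on an aromatic carbon. Among the compounds with values here, no measured step touches a change on the aromatic ring, and the single measured step is unreadable, so nothing measured bears directly on this change. The expectation for compound 3 in this assay is therefore a value near the same limit, estimated at 150000 nM with a range from 40000 nM to 1000000 nM. The step this estimate implies, a step that the limit leaves unreadable from compound 2 to compound 3, is expected to stay within the scatter.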

Compound 3, half-maximal inhibitory concentration: > 100000 nM
Compound 3 ended at the assay's limit; the forecaster's own chance of this, stated with the estimate: 80%; the middle value does not contradict the limit.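

Compound 3, like compound 2, gives only a limit in this assay and not a number, so no step between them can be read in size: the limit of > 100000 nM in this assay, at which 3 of the 3 values shown sit.

Whether swapping hydrogen for methoxy or (benzyloxy)methyl changes activity at all stays open: none of the compounds shown gives an actual number.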